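This account rests on a few compounds, and the source may have more. Where it says the series, first, only, none or still open, it means among the compounds named here.

For the measured compounds named here, compound 3 `O=C(O)COC/C=C1\C[C@H]2C[C@@H](O)[C@H](/C=N/NC(=O)Nc3ccccc3)[C@H]2C1` stands highest of the three numbers so far in a functional assay on a cell-free system (plasma) for agonist activity at thromboxane A2 receptor (Homo sapiens); on this read-out higher numbers stand for weaker inhibition and lower numbers for stronger inhibition; compound 3 gives 6000 nM. The step from compound 1 `O=C(O)COC/C=C1\C[C@H]2C[C@@H](O)[C@H](/C=N/NC(=O)Nc3ccc(Cl)c(Cl)c3)[C@H]2C1`, which gives 180 nM, is a 33-fold higher number from compound 1 to compound 3 (1.52 log units; beyond the scatter). Compound 2 `O=C(O)COC/C=C1/C[C@H]2C[C@@H](O)[C@H](/C=N/NC(=O)Nc3cccc(Cl)c3)[C@H]2C1` carries a differently substituted phenyl ring and the other drawn geometry of the exocyclic double bond; in this assay compound 2 gives 180 nM, the same number as compound 1. Compound 4 `O=C(O)COC/C=C1/C[C@H]2C[C@@H](O)[C@H](/C=N/NC(=O)Nc3ccccc3)[C@H]2C1` is obtained from compound 3 by the two compounds have the same atoms and bonds and differ only in configuration as drawn: 1 of 6 stereo elements differ; a double bond is drawn E in compound 3 and Z in compound 4. Going by the values given here, no measured step isolates this change; compound 1 and compound 2 combine it with a change on the phenyl ring and show no difference between them. For compound 4 no step beyond the scatter is therefore expected, no change at the digits printed from compound 3 to compound 4 (within the scatter). Compound 4 is estimated at 6000 nM, with a range from 2000 nM to 18000 nM.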

Compound 4, half-maximal inhibitory concentration: 1400 nM
For compound 4 the middle estimate is 4.3-fold (0.63 log units) above the measured one; measured number outside the range, below it.
By their numbers in this assay, from the lowest: compounds 1 and 2 (each within the scatter of the next); then compound 4; then compound 3.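

The geometry of the exocyclic double bond counts on its own in this assay, with a 4.3-fold lower number from compound 3 to compound 4 (0.63 log units; beyond the scatter). That step can be read on the double bond alone: the fact that compounds 3 and 4 differ only in the configuration as drawn. With the double bond drawn Z, the ring substituent also counts, with a 7.8-fold higher number from compound 2 to compound 4 (0.89 log units; beyond the scatter) on loss of the chloro group.

On these data alone, compound 1 and compound 2 differ in both places, so the size of the geometry step on a chlorinated phenyl ring stays open. Also open, as far as these compounds go, is how a methoxy group on the phenyl ring, or a tetrazole in place of the carboxylic acid, would read.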